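Inverting the Ring Stereocentre of Compound 3

The source may report more compounds than this note shows. Statements on the series, on what has been measured and on what is new or still open speak of the compounds shown alone.

Compound 3 `COc1ccc(/C=C\c2cc(OC)c(OC)c(OC)c2)cc1OCc1ccc(CN2CC[C@@H](O)C2)cc1` carries the 3-hydroxypyrrolidin-1-yl group on a saturated chain carbon bound to an aromatic carbon of the shared core. In a functional assay on HeLa cells (Homo sapiens) for antiproliferative activity, read by CCK-8 assay, with a stated time of 48 h (a higher number here means a weaker inhibitor, a lower number a stronger inhibitor), compound 3 gives > 10000 nM, which is a limit of the assay and not a number. Compound 1 `COc1ccc(/C=C\c2cc(OC)c(OC)c(OC)c2)cc1OCc1ccc(CN2C[C@H](O)C[C@@H]2C(=O)O)cc1` gives > 10000 nM in this assay, again a limit. Compound 2 `COc1ccc(/C=C\c2cc(OC)c(OC)c(OC)c2)cc1OCc1ccc(CN2CCCCC2C(=O)O)cc1` gives 14200 nM in this assay. The three connecting steps, a step that the limit leaves unreadable from compound 1 to compound 2, a step that the two limits leave unreadable from compound 1 to compound 3 and a step that the limit leaves unreadable from compound 2 to compound 3, cannot be sized because of the limit of > 10000 nM in this assay, at which 2 of the 3 values shown sit. Compound 4 `COc1ccc(/C=C\c2cc(OC)c(OC)c(OC)c2)cc1OCc1ccc(CN2CC[C@H](O)C2)cc1` differs from compound 3 only in configuration: the two compounds have the same atoms and bonds and differ only in configuration as drawn: 1 of 2 stereo elements differ; a stereocentre at a saturated ring carbon is drawn R in compound 3 and S in compound 4. Among the compounds with values here, no measured step alters a stereocentre alone, so none bears directly on this change, and the unreadable steps give no scale to borrow. Compound 4 is expected to stand where compound 3 stands, most likely returning a limit once more. The expected step is a step that the limit leaves unreadable from compound 3 to compound 4, nothing beyond the scatter. The estimate for compound 4 in this assay is 15000 nM, ranging from 7000 nM to 40000 nM.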

Compound 4, half-maximal inhibitory concentration: 10500 nM
The estimate for compound 4 lay 1.4-fold (0.15 log units) above the measured number, and the stated range covers the measured number.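

With compound 4, the 3-hydroxypyrrolidin-1-yl group gives a readable step in this assay, a 1.4-fold lower number from compound 2 to compound 4 (0.13 log units; within the scatter), so this group and 2-carboxypiperidin-1-yl are not told apart on the saturated chain carbon. Compound 3 remains at > 10000 nM, which is a limit of the assay and not a number. The step from compound 3 to compound 4 and the steps from compound 1 cannot be read: the limit of > 10000 nM in this assay, at which 2 of the 4 values shown sit.

Going by these compounds, whether the configuration at the saturated ring carbon shifts the number stays open, and this pair is the one that isolates it: the fact that compounds 3 and 4 differ only in the configuration as drawn Also open is how a dimethylamino or morpholin-4-yl group would read in place of the 3-hydroxypyrrolidin-1-yl group on the same chain carbon.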